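Hydroxy in place of fluoro: notes on the series

A few compounds are considered here, and "the series" means these few. Any claim that something is new, unique, unknown or untested is made for them only; others in the source may bear on it.

Measured so far in a functional assay on HepG2 cells (Mus musculus) for antiproliferative activity against HepG2 (Homo sapiens), read by MTT assay, with a stated time of 48 h; a lower number here means a stronger inhibitor, a higher number a weaker inhibitor:
compound 1 `COc1cccc(C(=O)Nc2nnc(/C=C/c3cc(OC)c(OC)c(OC)c3Br)s2)c1` gives 120 nM
compound 2 `COc1ccc(C(=O)Nc2nnc(/C=C/c3cc(OC)c(OC)c(OC)c3Br)s2)cc1` gives 220 nM
compound 3 `COc1cc(/C=C/c2nnc(NC(=O)c3cccc(F)c3)s2)c(Br)c(OC)c1OC` gives 170 nM

Compound 3 stands within the scatter of both other compounds: a 1.4-fold higher number from compound 1 to compound 3 (0.15 log units; within the scatter) and a 1.3-fold lower number from compound 2 to compound 3 (0.11 log units; within the scatter) are small steps. The remaining step, a 1.8-fold higher number from compound 1 to compound 2 (0.26 log units; within the scatter), is also within the scatter.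

Compound 4 `COc1cc(/C=C/c2nnc(NC(=O)c3cccc(O)c3)s2)c(Br)c(OC)c1OC` differs from compound 3 by hydroxy in place of fluoro on an aromatic carbon as hydroxy in place of fluoro on an aromatic carbon, meta to a large group. The nearest evidence is a 1.4-fold higher number from compound 1 to compound 3 (0.15 log units; within the scatter) for fluoro in place of methoxy. For the measured compounds named here, no hydroxy compound has been measured yet.

The estimated step is a 1.1-fold higher number from compound 3 to compound 4 (0.05 log units; within the scatter) and none beyond the scatter is expected in this assay. For compound 4 the estimated value is 190 nM with an expected range of 70 nM to 520 nM.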

Compound 4, half-maximal inhibitory concentration: 220 nM
The estimate for compound 4 lay 1.2-fold (0.06 log units) below the measured number; the range from low to high includes it.
By their numbers in this assay, from the lowest: compounds 1, 3, 2 and 4 (each within the scatter of the next).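

In this assay, hydroxy in place of fluoro on an aromatic carbon, meta to a large group, leaves the result within the scatter (a 1.3-fold higher number from compound 3 to compound 4 (0.11 log units; within the scatter)). Hydrogen in place of methyl on the oxygen (a 1.8-fold higher number from compound 1 to compound 4 (0.26 log units; within the scatter)) and 3-hydroxyphenyl in place of 4-methoxyphenyl (no change at the digits printed from compound 2 to compound 4 (within the scatter)) also stay within it, so this position has now carried fluoro, methoxy and hydroxy without a step beyond the scatter. Nothing available explains these numbers. Going by these compounds, whether an amine or a carboxylic acid at this position would also stay within the scatter remains open.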